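Lengthening the chain on compound 3: what to expect

A few compounds are considered here, and "the series" means these few. Any claim that something is new, unique, unknown or untested is made for them only; others in the source may bear on it.

Three compounds have been measured so far:
compound 1 `CCCn1cnc2c(N)nc(NCCCc3ccccc3)nc21`, 3640 nM;
compound 2 `CCCn1c(Br)nc2c(N)nc(NCCCc3ccccc3)nc21`, 583 nM;
compound 3 `CCCn1c(-c2ccco2)nc2c(N)nc(NCc3ccccc3)nc21`, 138 nM.

All three were tested in an assay on CHO cells for displacement of a labelled ligand from adenosine receptor A1 (Homo sapiens); on this read-out higher numbers stand for weaker inhibition and lower numbers for stronger inhibition. Compound 3 gives the lowest number of the three; compound 2 comes nearest, and compound 1 lies furthest away. Within the data shown here, the only step between compounds that differ in a single place is a 6.2-fold lower number from compound 1 to compound 2 (0.80 log units; beyond the scatter), which follows bromo in place of hydrogen on an aromatic carbon.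

Compound 4 `CCCn1c(-c2ccco2)nc2c(N)nc(NCCCc3ccccc3)nc21` is the next compound to be measured. It differs from compound 3 by phenethyl in place of phenyl on a saturated chain carbon bound to a nitrogen on an aromatic ring. Among the measured compounds shown here, no measured pair isolates this change: compounds 1 and 2 both carry the longer chain, but each differs from compound 3 in a second place as well, so their values only show that the longer chain is compatible with the shared core. For the measured compounds named here, the one measured step does not bear on a chain change at all. Going by the values given here, with no direct precedent, the expectation for compound 4 in this assay is a small step, likely within the scatter, possibly toward a slightly higher number, so that the estimated step is a 1.4-fold higher number from compound 3 to compound 4 (0.16 log units; within the scatter). Compound 4 is thus expected to give about 200 nM, within a range from 50 nM to 800 nM.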

Compound 4, inhibition constant: 230 nM
Compound 4: the middle estimate sits 1.2-fold (0.06 log units) below what was measured, and the stated range covers the measured number.
By their numbers in this assay, from the lowest: compounds 3 and 4 (each within the scatter of the next); then compound 2; then compound 1.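

In this assay, phenethyl in place of phenyl on a saturated chain carbon bound to a nitrogen on an aromatic ring gives a 1.7-fold higher number from compound 3 to compound 4 (0.22 log units; within the scatter), so with furan-2-yl on the shared core, this position accepts the longer chain without a change beyond the scatter. Compound 4 also allows the group on the aromatic carbon to be compared with the 3-phenylpropyl chain held constant: furan-2-yl in place of bromo gives a 2.5-fold lower number from compound 2 to compound 4 (0.40 log units; beyond the scatter), and furan-2-yl in place of hydrogen gives a 16-fold lower number from compound 1 to compound 4 (1.20 log units; beyond the scatter). Both of these steps lie beyond the scatter, and the step from hydrogen to furan-2-yl is much larger than the step that comes with the chain change, so among these compounds the group on the aromatic carbon has the greater effect on the number.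

As far as these compounds go, it remains open whether a still longer chain, or a chain ending in an amine or a carboxylic acid, would keep the number in this range, and whether the longer chain would be accepted as well with a methyl group on the aromatic carbon. Nothing available here offers an explanation for any of these steps.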